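Solubility notes: methoxy to trifluoromethyl on compound 2

The compounds below may be only part of what the source reports. "The series", "measured", "known", "first", "only" and "open" are said of these compounds alone.

Measured so far in a physicochemical assay for solubility; a higher number here means a more soluble compound, a lower number a less soluble compound:
Compound 1, `N#Cc1ccc(-n2c(=O)n(Cc3ccccc3)c3cccnc32)cc1C(F)(F)F`, gives < 500 nM, and this is a limit of the assay rather than a number.
Compound 2, `CNC(=O)c1ccc(-c2ccc3c(c2)C(C)(C)C(=O)N3c2ccc(C#N)c(OC)c2)cc1F`, gives 9700 nM.
Compound 3, `N#CCn1c(=O)n(-c2ccc(C#N)c(C(F)(F)F)c2)c2ccccc21`, gives 18900 nM.

Compound 2 holds the lower of the two numbers available in this assay, but its nearest neighbour, compound 3, sits within the scatter of it, so the two cannot be ordered. The remaining entry, for compound 1, is a limit only, as the limit of < 500 nM in this assay, at which 1 of the 3 values shown sits, records. No two of the measured compounds differ in a single place, so no measured step exists in this set and no cause can be assigned to any difference between them.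

Compound 4, `CNC(=O)c1ccc(-c2ccc3c(c2)C(C)(C)C(=O)N3c2ccc(C#N)c(C(F)(F)F)c2)cc1F`, is compound 2 with one change: trifluoromethyl in place of methoxy on an aromatic carbon. The change sits ortho to a cyano group and meta to a large group.

Among the measured compounds shown here, with no measured step to lean on, the expectation for this change is a modest fall in this assay, likely at the edge of the scatter, and the uncertainty is wide, since the two number-bearing values and the one limit span a broad range. Compound 4 is thus estimated at 4000 nM, with a range from 1000 nM to 15000 nM, which corresponds to an expected step of a 2.4-fold lower number from compound 2 to compound 4 (0.38 log units; beyond the scatter).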

Compound 4, solubility: 6250 nM
For compound 4 the middle estimate is 1.6-fold (0.19 log units) below the measured one, and the stated range covers the measured number.
By their numbers in this assay, from the lowest: compounds 4, 2 and 3 (each within the scatter of the next, the first and the last beyond it). At a limit, below all of these: compound 1.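

The series now holds its first step that differs in one place, and in this assay trifluoromethyl in place of methoxy on an aromatic carbon, ortho to a cyano group and meta to a large group, gives a 1.6-fold lower number from compound 2 to compound 4 (0.19 log units; within the scatter) and so does not separate the two compounds. At this position, a group of 4 heavy atoms with 0 hydrogen-bond acceptors therefore stands in for one of 2 heavy atoms with 1 hydrogen-bond acceptor with no difference that can be told from the scatter, a reading that holds for this one pair on this one core. Nothing measured here bears on a cause for this outcome.

A single step leaves open how this assay would read with a different kind of group on the same aromatic carbon, such as an amine, a carboxylic acid or a longer ether chain. It also leaves open whether methoxy in place of trifluoromethyl on the cores of compound 1 and compound 3 would give a step of similar size.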